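Adding a Hydroxy Group to Compound 1

This account rests on a few compounds, and the source may have more. Where it says the series, first, only, none or still open, it means among the compounds named here.

In a functional assay on Gurav cells (Homo sapiens) for inhibition, read by sulforhodamine B assay (a higher number here means a weaker inhibitor of growth, a lower number a stronger inhibitor of growth), compound 1 (`FC(F)(F)Oc1ccc(-c2ccc(-c3ccc(-c4nc5ccccc5[nH]4)cc3)cc2)cc1`) gives 100000 nM and stands highest of the two measured numbers, while compound 2 (`COc1ccc(-c2ccc(-c3ccc(-c4nc5ccccc5[nH]4)cc3)cc2)cc1`) gives 38100 nM. Compound 3 (`Oc1cccc2[nH]c(-c3ccc(-c4ccc(-c5ccc(OC(F)(F)F)cc5)cc4)cc3)nc12`) differs from compound 1 by one change (hydroxy in place of hydrogen on an aromatic carbon), hydroxy in place of hydrogen on an aromatic carbon, turning 1H-benzimidazol-2-yl into 4-hydroxy-1H-benzimidazol-2-yl. For the measured compounds named here, the only measured step (a 2.6-fold lower number from compound 1 to compound 2 (0.42 log units; beyond the scatter)) lies at a different place, so it bears only loosely on this change. A modest move to a lower number is expected (a 2.5-fold lower number from compound 1 to compound 3 (0.40 log units; beyond the scatter)) on that limited evidence. Compound 3 is estimated at 40000 nM within an expected range of 10000 nM to 100000 nM for this read-out.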

Compound 3, concentration for 50% growth inhibition: 3600 nM
Estimate against measurement, compound 3: 11-fold (1.05 log units) above, outside the stated range (below it).
By their numbers in this assay, from the lowest: compound 3; then compound 2; then compound 1.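

In this assay, hydroxy in place of hydrogen on an aromatic carbon gives a 28-fold lower number from compound 1 to compound 3 (1.44 log units; beyond the scatter), a large step, whereas the earlier change of the group on oxygen gave only a modest one, a 2.6-fold lower number from compound 1 to compound 2 (0.42 log units; beyond the scatter). For the compounds shown here, this shows that this carbon of the six-membered aromatic ring, untouched in the earlier compounds, strongly affects growth inhibition. No measurement shown here accounts for the size of this step. The compounds shown leave open whether an amine or a carboxylic acid on the same carbon would give a comparable step. They also leave open whether hydroxy there would have the same effect on compound 2.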